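The compounds below may be only part of what the source reports. "The series", "measured", "known", "first", "only" and "open" are said of these compounds alone.

Measured compounds:
compound 1, `O=C(NO)c1ccc(NCc2nc(-c3cccnc3)nn2-c2ccccc2)cc1`, giving 57.7% in an assay on Sf9 cells for inhibition of protein deacetylase HDAC6 (Homo sapiens), read by fluorescence, with a stated time of 40 min, tested at 100 nM; on this read-out lower numbers stand for less inhibition and higher numbers for more inhibition at the one concentration tested (going by the name of the read-out)
compound 2, `Cc1cc(C)cc(-n2nc(-c3ccccc3)nc2CNc2ccc(C(=O)NO)cc2)c1`, giving 49.8% in this assay

Compound 1 holds the larger of the two numbers, but the gap to compound 2 lies within the usual scatter, so the two cannot be told apart on these data. Among the compounds with values here, no step between measured compounds that differ in one place exists here, so nothing is known about what a single change at the core does to the read-out.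

Compound 3, `O=C(NO)c1ccc(NCc2nc(-c3ccncc3)nn2-c2ccccc2)cc1`, has not yet been measured. It differs from compound 1 in one place: pyridin-4-yl in place of pyridin-3-yl on an aromatic carbon. Within the data shown here, with no measured step of this kind to lean on, the step from compound 1 to compound 3 is expected to be small, in no settled direction, and not beyond the scatter; the estimate a number 2.7 percentage points lower from compound 1 to compound 3 (within the scatter) expresses this. Compound 3 is therefore estimated to give about 55% in this assay, within a range from 35% to 75%.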

Compound 3, a percentage reported as inhibition, at one concentration (the size of the read-out at that concentration, not a potency): 30.8%
Compound 3: the middle estimate sits 24.2 percentage points above what was measured; measured number outside the range, below it.
By their numbers in this assay, from the lowest: compound 3; then compounds 2 and 1 (each within the scatter of the next).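

In this assay, within the data shown here, the aromatic carbon between two ring nitrogen atoms proves sensitive to a change that leaves the atoms of the group untouched: with pyridin-4-yl in place of pyridin-3-yl, the read-out shows a number 26.9 percentage points lower from compound 1 to compound 3 (beyond the scatter), the first single change that can be read at this position. The two groups match in heavy atoms, hydrogen-bond donors and hydrogen-bond acceptors, so these counts alone do not settle the read-out here. Nothing measured here bears on why the pyridin-4-yl group gives the lower number.

Going by these compounds, whether pyridin-2-yl or a pyrimidine ring at this position would stay nearer to compound 1 or to compound 3 remains open. On these data alone, it is also open whether the same step would appear with a group other than phenyl on the ring nitrogen of the shared core.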